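This account rests on a few compounds, and the source may have more. Where it says the series, first, only, none or still open, it means among the compounds named here.

Measured compounds:
compound 1 `CCC(O)Cc1cc(-c2ccnc3[nH]nc(C(F)(F)F)c23)cc(C2(C#N)CC2)c1`, 49 nM
compound 2 `N#CC1(c2cc(CC(O)C3CC3)cc(-c3ccnc4[nH]nc(C(F)(F)F)c34)c2)CC1`, 30 nM
compound 3 `N#CC1(c2cc(CC(O)C(F)(F)F)cc(-c3ccnc4[nH]nc(C(F)(F)F)c34)c2)CC1`, 267 nM

All three share one core and differ only in the group on a saturated chain carbon bound to an oxygen on a saturated carbon and a saturated chain carbon. In an assay on isolated protein for inhibition of protein kinase C epsilon type (Homo sapiens), read by coupled enzyme assay (on this read-out higher numbers stand for weaker inhibition and lower numbers for stronger inhibition), compound 3 stands with the highest number of the three: there is a 5.4-fold higher number from compound 1 to compound 3 (0.74 log units; beyond the scatter) and an 8.9-fold higher number from compound 2 to compound 3 (0.95 log units; beyond the scatter). Between the other two the difference is small, with a 1.6-fold lower number from compound 1 to compound 2 (0.21 log units; within the scatter).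

Compound 4 `COCC(O)Cc1cc(-c2ccnc3[nH]nc(C(F)(F)F)c23)cc(C2(C#N)CC2)c1` has not yet been measured. It differs from compound 3 by methoxymethyl in place of trifluoromethyl on a saturated chain carbon bound to an oxygen on a saturated carbon and a saturated chain carbon. The two measured steps that bear on this both replaced a plain carbon group by trifluoromethyl and both raised the number beyond the scatter. The step from compound 3 to compound 4 removes that trifluoromethyl again, so the number in this assay is expected to fall back toward the range of compounds 1 and 2, because a 5.4-fold higher number from compound 1 to compound 3 (0.74 log units; beyond the scatter) and an 8.9-fold higher number from compound 2 to compound 3 (0.95 log units; beyond the scatter) both ran upward. Methoxymethyl has not been tested here, so some uncertainty remains. In this assay compound 4 is expected to give about 60 nM, estimated to lie between 25 nM and 150 nM. That expected step is a 4.5-fold lower number from compound 3 to compound 4 (0.65 log units; beyond the scatter).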

Compound 4, inhibition constant: 77 nM
Beside the measured number, compound 4's estimate is 1.3-fold (0.11 log units) below it; the range from low to high includes it.
By their numbers in this assay, from the lowest: compounds 2, 1 and 4 (each within the scatter of the next, the first and the last beyond it); then compound 3.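

Before compound 4, trifluoromethyl had been compared at this position only with ethyl and cyclopropyl, and methoxymethyl, which brings in an oxygen and one hydrogen-bond acceptor, now adds a different kind of replacement, with a 3.5-fold lower number from compound 3 to compound 4 (0.54 log units; beyond the scatter) in this assay. Measured against the ethyl of compound 1, the swap of methyl for methoxy at the end of the chain gives a 1.6-fold higher number from compound 1 to compound 4 (0.20 log units; within the scatter), so this assay cannot separate these two compounds, and an oxygen at this point in the chain leaves the number within the usual spread of repeat measurements. Against the cyclopropyl of compound 2, however, there is a 2.6-fold higher number from compound 2 to compound 4 (0.41 log units; beyond the scatter), so cyclopropyl and methoxymethyl can be told apart here, even though compound 1 lies within the scatter of both.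

Nothing shown here explains why these groups fall in this order. Going by these compounds, it also stays open how an amine such as aminomethyl, a carboxylic acid or a longer ether chain such as ethoxymethyl would read at this position.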